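Chloro for fluoro on the benzamide ring of compound 2

This account rests on a few compounds, and the source may have more. Where it says the series, first, only, none or still open, it means among the compounds named here.

The shared core is held constant through three measured benzamides: compound 1 `O=C(Nc1cc(-c2ccccc2)nn1-c1ccccc1)c1ccccc1` with an unsubstituted phenyl on the carbonyl, compound 2 `O=C(Nc1cc(-c2ccccc2)nn1-c1ccccc1)c1cccc(F)c1` with a 3-fluorophenyl, and compound 3 `O=C(Nc1cc(-c2ccccc2)nn1-c1ccccc1)c1ccc(C(F)(F)F)cc1` with a 4-(trifluoromethyl)phenyl. In an assay on CHO cells with metabotropic glutamate receptor 5 (Homo sapiens) as the target (a higher number here means that more compound is needed for the effect, a lower number that less compound is needed), compound 1 gives 40 nM, compound 2 gives 20 nM and compound 3 gives 19 nM. Compound 2 stands second highest of the three numbers; the step of a 1.1-fold lower number from compound 2 to compound 3 (0.02 log units; within the scatter) is within the scatter, and the step of a 2.0-fold lower number from compound 1 to compound 2 (0.30 log units; within the scatter) is also within the scatter, so the three sit close together.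

Compound 4 `O=C(Nc1cc(-c2ccccc2)nn1-c1ccccc1)c1cccc(Cl)c1` differs from compound 2 in one place: chloro in place of fluoro on an aromatic carbon. Among the compounds with values here, no measured step exchanges one halogen for another. Within the data shown here, the steps that bear on it are a 2.0-fold lower number from compound 1 to compound 2 (0.30 log units; within the scatter) and a 2.1-fold lower number from compound 1 to compound 3 (0.32 log units; beyond the scatter), both small, and a 1.1-fold lower number from compound 2 to compound 3 (0.02 log units; within the scatter), within the scatter, so substituents on this ring have moved the number only slightly. In this assay compound 4 is therefore expected to show no step beyond the scatter, at most a slightly lower number, a step of a 1.2-fold lower number from compound 2 to compound 4 (0.07 log units; within the scatter). Compound 4 is estimated at 17 nM, within 8 nM to 40 nM.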

Compound 4, half-maximal effective concentration: 40 nM
Beside the measured number, compound 4's estimate is 2.4-fold (0.37 log units) below it, and the stated range covers the measured number.
By their numbers in this assay, from the lowest: compounds 3, 2, 1 and 4 (each within the scatter of the next, the first and the last beyond it).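

In this assay, chloro in place of fluoro on this ring reads as a 2.0-fold higher number from compound 2 to compound 4 (0.30 log units; within the scatter), and chloro in place of hydrogen reads as no change at the digits printed from compound 1 to compound 4 (within the scatter), so this direct halogen exchange stays within the scatter and the chloro compound cannot be told apart from either neighbour. Within the data shown here, the one step from compound 4 beyond the scatter, and only a modest one, is a 2.1-fold higher number from compound 3 to compound 4 (0.32 log units; beyond the scatter), and it changes both the group and its place on the ring, so it cannot be assigned to either change alone. No measurement shown here accounts for these numbers.

Still open, on these data alone, is whether any group on this ring gives more than a modest step; an amine or a carboxylic acid at this place would test that. As far as these compounds go, a 4-chlorophenyl on the carbonyl would separate the effect of the group from that of its place, and the phenyl groups on the shared core remain unexplored.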